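The compounds below may be only part of what the source reports. "The series", "measured", "known", "first", "only" and "open" are said of these compounds alone.

Compound 1 `CCc1cc(S(=O)(=O)N2C[C@H](c3ccccc3)NC2=O)ccc1NC(=O)OC(C)C`: 60 nM
Compound 2 `CCCCOC(=O)Nc1ccc(S(=O)(=O)N2C[C@H](c3ccccc3)NC2=O)cc1CC`: 200 nM
Compound 3 `CCc1cc(S(=O)(=O)N2C[C@H](c3ccccc3)NC2=O)ccc1NC(=O)c1ccc([N+](=O)[O-])cc1`: 800 nM

These three compounds share one core and differ only in the group on a carbonyl carbon whose other neighbour is an amide-type nitrogen. In a functional assay on NCI-H460 cells (Homo sapiens) for cytotoxicity, read by MTT assay (a lower number here means a stronger inhibitor, a higher number a weaker inhibitor), compound 3 gives the highest number of the three, so it is the weakest inhibitor here: the step of a 13-fold higher number from compound 1 to compound 3 (1.12 log units; beyond the scatter) is large, and the step of a 4.0-fold higher number from compound 2 to compound 3 (0.60 log units; beyond the scatter) is modest, both beyond the scatter.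

Compound 4 `CCc1cc(S(=O)(=O)N2C[C@H](c3ccccc3)NC2=O)ccc1NC(=O)OCC(C)C` has not been measured. Its change from compound 3 is isobutoxy in place of 4-nitrophenyl on a carbonyl carbon. This runs opposite to the two measured steps into compound 3, in which 4-nitrophenyl replaced isopropoxy or butoxy; isobutoxy, like those two groups, has no ring. A drop in the number is therefore expected, of a size between those two steps, toward a stronger inhibitor. The estimated step is a 7.3-fold lower number from compound 3 to compound 4 (0.86 log units; beyond the scatter). For compound 4 the value expected in this assay is 110 nM, with a range from 40 nM to 300 nM.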

Compound 4, half-maximal inhibitory concentration: 80 nM
For compound 4 the middle estimate is 1.4-fold (0.14 log units) above the measured one; low and high end bracket the measured number.
By their numbers in this assay, from the lowest: compounds 1 and 4 (each within the scatter of the next); then compound 2; then compound 3.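

In this assay, replacing 4-nitrophenyl with isobutoxy on this carbonyl carbon gives a 10-fold lower number from compound 3 to compound 4 (1.00 log units; beyond the scatter), so a third group without a ring now stands well apart from the 4-nitrophenyl group. The shape of the chain also counts here: the branched isobutoxy of compound 4 and the unbranched butoxy of compound 2 are separated by a 2.5-fold lower number from compound 2 to compound 4 (0.40 log units; beyond the scatter), while the two branched groups are not separated, with a 1.3-fold higher number from compound 1 to compound 4 (0.12 log units; within the scatter) lying within the scatter. No measured evidence explains these differences.

The compounds shown cannot tell whether the higher number of compound 3 goes with the ring or with its nitro group, which a plain phenyl group on the same carbonyl carbon could help to separate. Going by these compounds, how a cyclohexyloxy or a tert-butoxy group would read at this position also remains open.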